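The compounds below may be only part of what the source reports. "The series", "measured", "known", "first", "only" and "open" are said of these compounds alone.

Measured so far in an ADME assay on the whole organism (strain FVB) for pharmacokinetics, with Mus musculus as the target, read by LC-MS, at a dose of 30 mg/kg by the oral route; a higher number here means more compound in the circulation at the dose given, a lower number less compound in the circulation:

Compound 1 `NCCOc1ccc([C@H]2CC[C@]3(CC2)OOC2(O3)C3CC4CC(C3)CC2C4)cc1`: 287 nM
Compound 2 `c1cc([C@H]2CC[C@]3(CC2)OOC2(O3)C3CC4CC(C3)CC2C4)ccc1OCC1CCNCC1`: 465 nM

Compound 2 stands at 465 nM and compound 1 at 287 nM, so the two lie within the scatter of each other and neither can be ranked over the other. Compound 3 `O[C@H]1CC[C@H](NCCCOc2ccc([C@H]3CC[C@]4(CC3)OOC3(O4)C4CC5CC(C4)CC3C5)cc2)CC1` has not yet been measured. It keeps the shared core of compound 2 and differs in its side chain: 2-((4-hydroxycyclohexyl)amino)ethyl in place of piperidin-4-yl on a saturated chain carbon bound to an oxygen on an aromatic ring. In words, 2-((4-hydroxycyclohexyl)amino)ethyl stands in place of piperidin-4-yl on a saturated chain carbon bound to an oxygen on an aromatic ring.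

Among the measured compounds shown here, only one measured step bears on this change. It falls at the same place, where piperidin-4-yl replaced aminomethyl, and it is a 1.6-fold higher number from compound 1 to compound 2 (0.21 log units; within the scatter). For the measured compounds named here, no measured compound carries the incoming group, which leaves that single step as thin support. Going by the values given here, with nothing beyond the scatter at this place so far, the expected step is a 1.6-fold lower number from compound 2 to compound 3 (0.19 log units; within the scatter), with no real shift anticipated in this assay. Compound 3 is estimated at 300 nM, with an expected range from 90 nM to 900 nM.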

Compound 3, maximal plasma concentration: 721 nM
Compound 3: the middle estimate sits 2.4-fold (0.38 log units) below what was measured, and the stated range covers the measured number.
By their numbers in this assay, from the lowest: compounds 1, 2 and 3 (each within the scatter of the next, the first and the last beyond it).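

In this assay, the piperidin-4-yl group can give way to the larger 2-((4-hydroxycyclohexyl)amino)ethyl group, which has a carbon-only six-membered ring and two defined stereocentres, with a 1.6-fold higher number from compound 2 to compound 3 (0.19 log units; within the scatter), so this change on a saturated chain carbon bound to an oxygen on an aromatic ring cannot be told from no change at all. Among the compounds shown here, the comparison with the simple primary amine of compound 1 goes further: placing ((4-hydroxycyclohexyl)amino)methyl on the amino position gives a 2.5-fold higher number from compound 1 to compound 3 (0.40 log units; beyond the scatter), the first step to clear the scatter, though only modestly, and it shows that the small amine and the large substituted one are not equivalent at this place. Nothing available explains this step, neither a measured property nor any other supporting result.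

Still open, from the compounds shown here alone, is which part of the new side chain carries that step, the hydroxy group, the cyclohexyl ring or the longer chain, as compound 3 changes all of them at once. A cyclohexylamino chain without the hydroxy group, or a morpholine on the same chain, would begin to separate these parts.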